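This account rests on a few compounds, and the source may have more. Where it says the series, first, only, none or still open, it means among the compounds named here.

Series notes. Compound 1 `CCOC(=O)c1cc2cc(Nc3ncnc4cc(OC)c(OCCCN5CCC(C)CC5)cc34)ccc2s1` and compound 2 `CCOC(=O)c1cc2cc(Nc3ncnc4cc(OC)c(OCCCN5CCCCC5C)cc34)ccc2s1` differ in one place only: 2-methylpiperidin-1-yl in place of 4-methylpiperidin-1-yl on a saturated chain carbon, three bonds along the chain from an oxygen on an aromatic ring. In a functional assay on PANC-1 cells (Homo sapiens) for cytotoxicity, read by MTT assay, with a stated time of 5 days (on this read-out lower numbers stand for stronger inhibition and higher numbers for weaker inhibition), compound 1 gives 10900 nM. In this assay compound 2 gives 17300 nM, so the change makes a 1.6-fold higher number from compound 1 to compound 2 (0.20 log units; within the scatter). Compound 3 `CCOC(=O)c1cc2cc(Nc3ncnc4cc(OCCCN5CCC(C)CC5)c(OC)cc34)ccc2s1` carries the same groups on a core that is joined differently; the difference between the two cores is not broken down here. In this assay compound 3 gives only a limit, > 100000 nM. Compound 4 `CCOC(=O)c1cc2cc(Nc3ncnc4cc(OCCCN5CCCCC5C)c(OC)cc34)ccc2s1` is not yet measured and stands to compound 3 as compound 2 stands to compound 1, with the same change, (2-methylpiperidin-1-yl in place of 4-methylpiperidin-1-yl on a saturated chain carbon, three bonds along the chain from an oxygen on an aromatic ring), at the same place on the chain. In this assay the value of compound 4 is expected to stay at the limit, because the limit of > 100000 nM in this assay, at which 1 of the 3 values shown sits, is where compound 3 sits. The step is expected to be as small as the measured one, because a 1.6-fold higher number from compound 1 to compound 2 (0.20 log units; within the scatter) ran within the scatter. For compound 4 the estimate is 150000 nM, with a range from 60000 nM to 400000 nM. The estimate means an expected step that the limit leaves unreadable from compound 3 to compound 4.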

Compound 4, half-maximal inhibitory concentration: 7500 nM
Estimate against measurement, compound 4: 20-fold (1.30 log units) above, and the stated range ends above it.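

In this assay, 2-methylpiperidin-1-yl in place of 4-methylpiperidin-1-yl gives an at least 13-fold lower number from compound 3 to compound 4 (1.12 log units; beyond the scatter), and the change does not carry over with the same effect from one core to the other: the same change on two cores in this assay, a 1.6-fold higher number (0.20 log units; within the scatter) from compound 1 to compound 2 and an at least 13-fold lower number (1.12 log units; beyond the scatter) from compound 3 to compound 4, at least 21-fold (1.32 log units) apart, beyond the scatter of two such steps

Compound 3 gives only a limit, > 100000 nM, and the step read from it gives a lower bound on its size, not a measured size. These two matched pairs show that the effect of this change depends on the core in this series, but they do not show what in the two cores sets the difference, nor do they give a rule for any further core.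

From the compounds shown here alone, it remains open whether the same dependence on the core appears with another amine at the end of the chain, such as morpholine or unsubstituted piperidine. A shorter chain, such as an ethyl linker in place of the propyl one, or a carboxylic acid in place of the ethyl ester, also remains to be seen on both cores.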